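This account rests on a few compounds, and the source may have more. Where it says the series, first, only, none or still open, it means among the compounds named here.

Compound 1 `CN(c1ncccc1CNc1nc(Nc2ccccc2)nc2[nH]cc(F)c12)S(C)(=O)=O` and compound 2 `CN(c1ncccc1CNc1nc(Nc2ccc(F)cc2)nc2[nH]cc(F)c12)S(C)(=O)=O` are the two measured compounds. In a functional assay on SMMC-7721 cells (Homo sapiens) for inhibition, read by MTT assay, with a stated time of 48 h (a lower number here means a stronger inhibitor, a higher number a weaker inhibitor), compound 1 gives only a limit, > 100000 nM, which is the end of the measurable range and not a number (the limit of > 100000 nM in this assay, at which 1 of the 2 values shown sits). In this assay compound 2 gives 27900 nM, the only number shown, so compound 2 stands as the sole measured point. Among the compounds with values here, the step of an at least 3.5-fold lower number from compound 1 to compound 2 (0.55 log units; beyond the scatter) is the one measured change.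

Compound 3 `CN1CCN(c2ccc(Nc3nc(NCc4cccnc4N(C)S(C)(=O)=O)c4c(F)c[nH]c4n3)cc2)CC1` differs from compound 2 by 4-methylpiperazin-1-yl in place of fluoro on an aromatic carbon, with the new group sitting para to a large group. Within the data shown here, no measured step exchanges fluoro for 4-methylpiperazin-1-yl, so the one known step bears on it only indirectly, as a sign that this part of compound 2 tolerates change. The expected step of a 3.5-fold lower number from compound 2 to compound 3 (0.54 log units; beyond the scatter) is a modest move toward stronger inhibition. Compound 3 is therefore estimated at 8000 nM, with a range from 1500 nM to 40000 nM.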

Compound 3, half-maximal inhibitory concentration: 13900 nM
For compound 3 the middle estimate is 1.7-fold (0.24 log units) below the measured one; measured number inside the range.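

In this assay, the change from fluoro to 4-methylpiperazin-1-yl on this aromatic carbon gives a 2.0-fold lower number from compound 2 to compound 3 (0.30 log units; within the scatter), so this place takes a group with a non-aromatic ring as well as it takes a single fluoro, and the assay does not separate the two. Set against hydrogen at the same carbon, 4-methylpiperazin-1-yl gives an at least 7.1-fold lower number from compound 1 to compound 3 (0.85 log units; beyond the scatter), so both substituents shown here yield a measurable number. That comparison has only a lower bound, since compound 1 gives a limit and not a number: the limit of > 100000 nM in this assay, at which 1 of the 3 values shown sits.

The compounds shown leave open whether a morpholine, an open-chain amine or a carboxylic acid at this carbon would read like fluoro and 4-methylpiperazin-1-yl. They also leave open how either group would read on another carbon of the same ring.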